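Adding a Methyl Group on an Aromatic Carbon

A few compounds are considered here, and "the series" means these few. Any claim that something is new, unique, unknown or untested is made for them only; others in the source may bear on it.

Of the compounds shown here, three sharing one core have been measured in an assay on isolated protein for inhibition of beta-glucuronidase (Bos taurus), read by spectrophotometry, with a stated time of 30 min; on this read-out higher numbers stand for weaker inhibition and lower numbers for stronger inhibition. Compound 1 `Clc1ccc(Nc2nnc(-c3ccccc3Cl)s2)cc1Cl` gives 2160 nM. Compound 2 `Brc1ccc(-c2nnc(Nc3ccccc3)s2)cc1` gives 40200 nM, and compound 3 `Cc1ccc(-c2nnc(Nc3cccc(Br)c3)s2)c(C)c1` gives 36100 nM. Among these three numbers compound 2 stands highest; its value and that of compound 3 lie within the usual scatter of each other, while compound 1 gives a clearly lower number, a gap beyond the scatter. Compound 4 `Cc1ccc(Nc2nnc(-c3ccc(Br)cc3)s2)cc1` has not yet been measured in this assay. It differs from compound 2 by methyl in place of hydrogen on an aromatic carbon. Within the data shown here, no measured pair shows this change alone, so only a small step is expected, likely within the scatter and at most slightly downward. Compound 4 is expected to give about 30000 nM in this assay, within a range from 10000 nM to 90000 nM. This corresponds to an expected step of a 1.3-fold lower number from compound 2 to compound 4 (0.13 log units; within the scatter).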

Compound 4, half-maximal inhibitory concentration: 28600 nM
Compound 4: middle estimate off by 1.0-fold (0.02 log units), on the high side; the range from low to high includes it.
By their numbers in this assay, from the lowest: compound 1; then compounds 4, 3 and 2 (each within the scatter of the next).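

In this assay this position now has a measured pair of its own: methyl in place of hydrogen on an aromatic carbon, para to a large group, gives a 1.4-fold lower number from compound 2 to compound 4 (0.15 log units; within the scatter). A step this small cannot be told apart from the usual scatter of repeated measurements, so this change shows no clear effect on the number here. Nothing available explains this result.

On these data alone, it remains open whether a longer chain or an amine or carboxylic acid on this carbon would move the number beyond the scatter.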